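The source may report more compounds than this note shows. Statements on the series, on what has been measured and on what is new or still open speak of the compounds shown alone.

Compound 1 `N=C(N)c1ccc(-c2ccc(-c3cc(Cl)cc(Cl)c3)s2)cc1` gives 1480 nM
Compound 2 `N=C(N)c1ccc(-c2ccc(-c3ccc(Cl)cc3)s2)cc1F` gives "not determined" (no result reported)
Compound 3 `COc1cc(OC)cc(-c2ccc(-c3ccc(C(=N)N)c(F)c3)s2)c1` gives "not determined" (no result reported)

The measurement in question is a functional assay on T47D cells (Homo sapiens) for inhibition, read by sulforhodamine B assay, with a stated time of 48 h; on this read-out higher numbers stand for weaker inhibition of growth and lower numbers for stronger inhibition of growth. Of the three compounds that have been tested, only compound 1 has been reported with a number: in this assay compound 1 gives 1480 nM. Compound 2 has no single number in this assay, and compound 3 is the further entry for which no number was reported either. Compound 2 therefore stands nowhere on the scale that compound 1 defines; the account has only one anchor.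

The step from compound 2 leads to compound 4 `COc1ccc(-c2ccc(-c3ccc(C(=N)N)c(F)c3)s2)cc1`, which is yet to be measured in this assay. The change is methoxy in place of chloro on an aromatic carbon. Between the measured compounds no step can be drawn, since only compound 1 carries a number, so the size of this step is not calibrated by anything here. Without a measured step, the expectation for compound 4 can only be anchored loosely on compound 1, whose reading in this assay is 1480 nM: a move of modest size in either direction, or none beyond the scatter, is plausible. On that basis, compound 4 is expected to give about 1200 nM in this assay, within a range from 350 nM to 4000 nM.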

Compound 4, concentration for 50% growth inhibition: 2920 nM
Estimate against measurement, compound 4: 2.4-fold (0.39 log units) below; the measured number falls inside the stated range.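

In this assay, among the compounds shown here, compound 4 gives 2920 nM, but compound 2 has no single number there, so no step from chloro to methoxy can be read between them. The compounds shown leave open what that replacement does to growth inhibition in this assay. No evidence is available that bears on the result of compound 4.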